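A fluorophenyl amine in place of the indolyl amine

A few compounds are considered here, and "the series" means these few. Any claim that something is new, unique, unknown or untested is made for them only; others in the source may bear on it.

Among the measured compounds shown here, compound 1 `COc1ccc(-c2nc(C(=O)/C=C\Nc3ccc4[nH]ccc4c3)c3ccccn23)cc1` stands at the top of the two numbers so far: in a functional assay on BT-474 cells (Homo sapiens) for cytotoxicity, read by MTT assay, with a stated time of 48 h (on this read-out lower numbers stand for stronger inhibition and higher numbers for weaker inhibition), compound 1 gives 13000 nM, the highest of the pair. For the measured compounds named here, its only measured neighbour, compound 2 `O=C(/C=C\Nc1ccc2[nH]ccc2c1)c1nc(-c2ccc(C(F)(F)F)cc2)n2ccccc12`, gives 5190 nM in this assay, and the step of a 2.5-fold lower number from compound 1 to compound 2 (0.40 log units; beyond the scatter) goes with trifluoromethyl in place of methoxy on an aromatic carbon.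

Compound 3 `COc1ccc(-c2nc(C(=O)/C=C\Nc3ccc(F)cc3)c3ccccn23)cc1` differs from compound 1 at a different place: 4-fluorophenyl in place of 1H-indol-5-yl on an amine nitrogen. Going by the values given here, no measured step touches the substituent on this amine nitrogen; the single step recorded, from compound 1 to compound 2, sits on the aromatic carbon at the other end of the shared core, so it does not bear on the present change. The shown numbers give no direction for the swap, and a step of unknown direction is best taken as small. The resulting step is therefore expected to be a 1.2-fold higher number from compound 1 to compound 3 (0.09 log units; within the scatter), inside the usual scatter. In this assay compound 3 is thus estimated to give 16000 nM, with a likely range from 5000 nM to 50000 nM.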

Compound 3, half-maximal inhibitory concentration: > 30000 nM
Compound 3 ended at the assay's limit (the forecaster's own chance of this, stated with the estimate: 15%); middle value at least 1.8-fold (0.27 log units) away from the limit.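

In this assay compound 3 gives > 30000 nM, which is a limit of the assay and not a number. The step on the amine nitrogen, an at least 2.3-fold higher number from compound 1 to compound 3 (0.36 log units; beyond the scatter), shows that this position responds to a change of group: with 4-fluorophenyl in place of 1H-indol-5-yl, inhibition weakens beyond the scatter, whereas the earlier step spoke only for the aromatic carbon at the other end of the shared core. The size of this step has a floor but no ceiling, since the reading of compound 3 stops at the limit: the limit of > 30000 nM in this assay, at which 1 of the 3 values shown sits.

A single swap cannot tell whether the weakening goes with the departure of the five-membered aromatic ring and its hydrogen-bond donor or with the arrival of the fluorine, and a plain phenyl or a 4-methoxyphenyl on the amine nitrogen would be needed to separate the two. As far as these compounds go, it also remains open whether the same swap has a like effect when trifluoromethyl stands in place of methoxy, as in compound 2.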